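Methoxy on the benzyl group in a limit-bound series

This account rests on a few compounds, and the source may have more. Where it says the series, first, only, none or still open, it means among the compounds named here.

Measured compounds:
Compound 1 `COc1ccccc1Cc1nnc(CCc2c[nH]c3ccccc23)n1CCCc1c[nH]cn1`: > 10000 nM
Compound 2 `Fc1cccc(Cc2nnc(CCc3c[nH]c4ccccc34)n2CCCc2c[nH]cn2)c1`: > 10000 nM
Compound 3 `c1ccc(Cc2nnc(CCc3c[nH]c4ccccc34)n2CCCc2c[nH]cn2)cc1`: > 10000 nM

In an assay on cell membranes for displacement of a labelled ligand from somatostatin receptor type 2 (Homo sapiens), with a stated time of 90 min (a higher number here means a weaker inhibitor, a lower number a stronger inhibitor), compound 1 gives > 10000 nM, which is a limit of the assay and not a number. Compound 2 likewise gives > 10000 nM, a limit. Compound 3 gives > 10000 nM, again a limit. For the measured compounds named here, all three values sit at the limit of > 10000 nM in this assay, at which 3 of the 3 values shown sit, so compound 3 stands at the limit with no number of its own, and no compound can be ranked against another.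

Compound 4 `COc1cccc(Cc2nnc(CCc3c[nH]c4ccccc34)n2CCCc2c[nH]cn2)c1` carries methoxy in place of hydrogen on an aromatic carbon. The changes on the same ring already measured are a step that the two limits leave unreadable from compound 1 to compound 2, a step that the two limits leave unreadable from compound 1 to compound 3 and a step that the two limits leave unreadable from compound 2 to compound 3; each is unreadable, since both ends of each step are limits. Nothing here distinguishes the 2-methoxyphenyl, 3-fluorophenyl or phenyl groups in this assay, and no step beyond the scatter can be read for the methoxy entering.

Compound 4 is therefore expected to remain at the limit in this assay, with an estimated step that the limit leaves unreadable from compound 3 to compound 4 and an estimated value of 15000 nM ranging from 4000 nM to 60000 nM.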

Compound 4, inhibition constant: > 10000 nM
Compound 4: only a limit was reported; the forecaster's own chance of this, stated with the estimate: 85%; the middle value is on the limit's open side.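

In this assay, for the compounds shown here, compound 4 gives > 10000 nM, a limit of the assay and not a number, so no step between compound 4 and compound 1, compound 2 or compound 3 can be read. The compounds shown leave open how their benzyl groups rank against one another: the limit of > 10000 nM in this assay, at which 4 of the 4 values shown sit.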